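The source may report more compounds than this note shows. Statements on the series, on what has been measured and on what is new or still open speak of the compounds shown alone.

Of the compounds shown here, three have been measured. Compound 1 `CCc1cn(-c2nc(NC)c3ncn([C@@H]4O[C@H](CO)[C@@H](O)[C@H]4O)c3n2)nn1` gives 13.8 nM in an assay on CHO cells for displacement of a labelled ligand from adenosine receptor A3 (Homo sapiens); a lower number here means a stronger inhibitor, a higher number a weaker inhibitor. Compound 2 `CCCCc1cn(-c2nc(NC)c3ncn([C@@H]4O[C@H](CO)[C@@H](O)[C@H]4O)c3n2)nn1` gives 11.7 nM in this assay. Among the compounds with values here, the only change between them is a 1.2-fold lower number from compound 1 to compound 2 (0.07 log units; within the scatter), a difference that stays within the scatter of the assay. Compound 3 `CCNC(=O)[C@H]1O[C@@H](n2cnc3c(NC)nc(-n4cc(CC5CCCC5)nn4)nc32)[C@H](O)[C@@H]1O` gives 11.5 nM in this assay, a number that sits alongside those of compound 2 and compound 1, with all three within the scatter of one another, so none of the three can be called stronger or weaker than the others.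

Compound 4 `CNc1nc(-n2cc(CC3CCCC3)nn2)nc2c1ncn2[C@@H]1O[C@H](CO)[C@@H](O)[C@H]1O` is not yet measured. It differs from compound 3 by hydroxymethyl in place of ethylcarbamoyl on a saturated ring carbon. Within the data shown here, no measured pair shows this change at the sugar; the one measured step concerns the chain on the triazole and so says nothing about this position. What can be drawn on is that compound 1 and compound 2 already carry the hydroxymethyl. Compound 1 gives 13.8 nM and compound 2 gives 11.7 nM, both close to compound 3. On that basis the expected step is a 1.7-fold higher number from compound 3 to compound 4 (0.24 log units; within the scatter), a shift not clearly beyond the scatter. Compound 4 is therefore estimated at 20 nM in this assay, with a plausible range from 6 nM to 65 nM.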

Compound 4, inhibition constant: 1.3 nM
The estimate for compound 4 lay 15-fold (1.19 log units) above the measured number; the whole stated range lies above it.
By their numbers in this assay, from the lowest: compound 4; then compounds 3, 2 and 1 (each within the scatter of the next).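

In this assay, the ring carbon next to the ring oxygen turns out to be sensitive: hydroxymethyl in place of ethylcarbamoyl gives an 8.8-fold lower number from compound 3 to compound 4 (0.95 log units; beyond the scatter), a step beyond the scatter, so the group at this position clearly affects the number. With hydroxymethyl kept, the end of the chain also matters: cyclopentyl in place of propyl gives a 9.0-fold lower number from compound 2 to compound 4 (0.95 log units; beyond the scatter), and cyclopentyl in place of methyl gives an 11-fold lower number from compound 1 to compound 4 (1.03 log units; beyond the scatter), whereas the earlier chain change gave only a 1.2-fold lower number from compound 1 to compound 2 (0.07 log units; within the scatter) and stayed within the scatter. The data shown offer no measurement that explains why either change lowers the number.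

Within the data shown here, still open is whether hydroxymethyl in place of ethylcarbamoyl would give a similar step on compounds carrying a propyl or methyl group in place of cyclopentyl, since this swap is seen only with cyclopentyl present. The compounds shown also leave open how a carboxylic acid or a methylcarbamoyl at this ring carbon, or a cyclohexyl group in place of cyclopentyl on the chain, would compare with compound 4 .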